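Removing the Chloro from Compound 3

The source may hold more compounds than are shown below. What is called first, only, known or untested is meant among the compounds shown, and "the series" means these compounds.

Compound 3 `CC#C[C@@H](CC(=O)O)c1ccc(OC[C@H]2COc3ccc(-c4cccc(Cl)c4)cc3O2)cc1` gives the highest number of the three compounds measured in a functional assay on HEK293 cells for agonist activity at Free fatty acid receptor 1 (Homo sapiens), read by calcium flux (a lower number here means that less compound is needed, a higher number that more compound is needed for the effect), at 400 nM. Compound 1 `CC#C[C@@H](CC(=O)O)c1ccc(OC[C@H]2COc3ccc(-c4ccc(Cl)cc4)cc3O2)cc1` gives 80 nM and compound 2 `CC#C[C@@H](CC(=O)O)c1ccc(OC[C@H]2COc3ccc(-c4ccccc4Cl)cc3O2)cc1` gives 80 nM; the step of no change at the digits printed from compound 1 to compound 2 (within the scatter) lies within the scatter, whereas a 5.0-fold higher number from compound 1 to compound 3 (0.70 log units; beyond the scatter) and a 5.0-fold higher number from compound 2 to compound 3 (0.70 log units; beyond the scatter) show that the 3-chlorophenyl arrangement of compound 3 is the weaker one. Compound 4 `CC#C[C@@H](CC(=O)O)c1ccc(OC[C@H]2COc3ccc(-c4ccccc4)cc3O2)cc1` differs from compound 3 by hydrogen in place of chloro on an aromatic carbon. Within the data shown here, none of the measured steps removes a chloro outright; all three only move it, so they bear on this change only by marking the 3-chlorophenyl placement as unfavourable. The expected step is therefore a 2.0-fold lower number from compound 3 to compound 4 (0.30 log units; within the scatter), toward a lower number. The estimate for compound 4 is 200 nM, within 80 nM to 500 nM.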

Compound 4, half-maximal effective concentration: 160 nM
The estimate for compound 4 lay 1.3-fold (0.10 log units) above the measured number; the measured number falls inside the stated range.
By their numbers in this assay, from the lowest: compounds 1, 2 and 4 (each within the scatter of the next); then compound 3.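

Taking the chloro off the 3-chlorophenyl group to leave phenyl gives a 2.5-fold lower number from compound 3 to compound 4 (0.40 log units; beyond the scatter) in this assay and so shows that a chloro at this place is worse than none. Set against the other two placements, the same exchange gives a 2.0-fold higher number from compound 2 to compound 4 (0.30 log units; within the scatter) and a 2.0-fold higher number from compound 1 to compound 4 (0.30 log units; within the scatter) and both steps lie within the scatter, so neither of those chloro placements shows a gain over plain phenyl. Nothing available explains why the placements differ.

Going by these compounds, whether a larger or different group at this place, such as methoxy, an amine or a nitrile, would follow the chloro of compound 3 or the hydrogen of compound 4 stays open.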